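This account rests on a few compounds, and the source may have more. Where it says the series, first, only, none or still open, it means among the compounds named here.

Working notes on the series. In a functional assay on DU-145 cells (Homo sapiens) for inhibition, read by WST assay, with a stated time of 3 days (on this read-out lower numbers stand for stronger inhibition and higher numbers for weaker inhibition), compound 1 `Cn1ccnc1/C=C/C(=O)/C=C/c1coc2ccccc2c1=O` gives 4500 nM, compound 2 `CCCCn1ccnc1/C=C/C(=O)/C=C/c1coc2ccccc2c1=O` gives 4300 nM and compound 3 `CC(C)n1ccnc1/C=C/C(=O)/C=C/c1coc2ccccc2c1=O` gives 3300 nM. Compound 3 cannot be separated from the other two on these numbers: the steps to it are a 1.4-fold lower number from compound 1 to compound 3 (0.13 log units; within the scatter) and a 1.3-fold lower number from compound 2 to compound 3 (0.11 log units; within the scatter).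

The next compound is compound 4 `CC(C)CCn1ccnc1/C=C/C(=O)/C=C/c1coc2ccccc2c1=O`, which differs from compound 3 as follows: isopentyl in place of isopropyl on an aromatic nitrogen. In short, isopentyl in place of isopropyl on an aromatic nitrogen, with the rest of the structure unchanged.

All three measured steps concern the group on this same nitrogen, so all three bear on the change. Besides the two steps above, there is a 1.0-fold lower number from compound 1 to compound 2 (0.02 log units; within the scatter). Methyl, butyl and isopropyl have therefore given no step beyond the scatter, and none of the three compounds goes against this. That is a small set, and isopentyl itself has not been tested. On this basis, no step beyond the scatter is expected in this assay, and no direction can be called. The estimated step is a 1.2-fold higher number from compound 3 to compound 4 (0.08 log units; within the scatter). For compound 4 the expected value is 4000 nM, with an estimated range of 2200 nM to 7000 nM.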

Compound 4, half-maximal inhibitory concentration: 5800 nM
For compound 4 the middle estimate is 1.5-fold (0.16 log units) below the measured one; the measured number falls inside the stated range.
By their numbers in this assay, from the lowest: compounds 3, 2, 1 and 4 (each within the scatter of the next).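

In this assay, the group on this aromatic nitrogen now reaches isopentyl, with 5 heavy atoms, and the change from isopropyl stays within the scatter (a 1.8-fold higher number from compound 3 to compound 4 (0.24 log units; within the scatter)). The two other steps to isopentyl are also within the scatter (a 1.3-fold higher number from compound 2 to compound 4 (0.13 log units; within the scatter); a 1.3-fold higher number from compound 1 to compound 4 (0.11 log units; within the scatter)), so methyl, butyl, isopropyl and isopentyl cannot be separated on these numbers, and none of the four compounds goes against this. This now covers a branched chain of the same size class as the straight butyl as well as the short groups, yet no evidence beyond these numbers bears on the result.

What stays open is whether any group on this nitrogen can give a step beyond the scatter, since all four groups shown are simple carbon chains with no ring. An amine or a carboxylic acid at the end of the chain, a phenyl ring, or a much longer chain such as octyl could each answer that, and the direction of any such step cannot be called from compounds 1 to 4.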